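A few compounds are considered here, and "the series" means these few. Any claim that something is new, unique, unknown or untested is made for them only; others in the source may bear on it.

Measured so far in a functional assay on NCI-H460 cells (Homo sapiens) for cytotoxicity, read by MTT assay, with a stated time of 72 h; a lower number here means a stronger inhibitor, a higher number a weaker inhibitor:
Compound 1, `CN(C)CCCNc1nc(-c2ccc(NC(=O)Nc3ccccc3F)cc2)nc2ccsc12`, gives 530 nM.
Compound 2, `CCN(CC)CCCNc1nc(-c2ccc(NC(=O)Nc3ccccc3F)cc2)nc2ccsc12`, gives 370 nM.

Compound 2 and compound 1 sit within the usual scatter of each other, since a 1.4-fold lower number from compound 1 to compound 2 (0.16 log units; within the scatter) is too small to separate them. Compound 3, `CCN(CC)CCNc1nc(-c2ccc(NC(=O)Nc3ccccc3F)cc2)nc2ccsc12`, differs from compound 2 by diethylamino in place of (diethylamino)methyl on a saturated chain carbon, two bonds along the chain from a nitrogen on an aromatic ring. Within the data shown here, no measured step touches the length of this chain; the only step, a 1.4-fold lower number from compound 1 to compound 2 (0.16 log units; within the scatter), concerns the amine at its end, and it was within the scatter. The expected step is therefore a 1.1-fold higher number from compound 2 to compound 3 (0.03 log units; within the scatter), with no change beyond the scatter. Compound 3 is estimated at 400 nM, between 150 nM and 1200 nM.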

Compound 3, half-maximal inhibitory concentration: 430 nM
Estimate against measurement, compound 3: 1.1-fold (0.03 log units) below; measured number inside the range.
By their numbers in this assay, from the lowest: compounds 2, 3 and 1 (each within the scatter of the next).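

Going from 3-(diethylamino)propyl to 2-(diethylamino)ethyl tests the length of this chain for the first time, and in this assay it gives a 1.2-fold higher number from compound 2 to compound 3 (0.07 log units; within the scatter). Shortening the chain and changing the end amine together gives a 1.2-fold lower number from compound 1 to compound 3 (0.09 log units; within the scatter), so across these compounds neither the chain length nor the end amine moves the number beyond the scatter. No measured evidence bears on these results. From the compounds shown here alone, a longer chain remains open, as does a carboxylic acid in place of the end amine.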